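A Methyl on the Acetoxy Chain of an Aryl Enone

The source may report more compounds than this note shows. Statements on the series, on what has been measured and on what is new or still open speak of the compounds shown alone.

Compound 1 `CCC(/C=C(\COC(C)=O)C(=O)c1ccc(OC)cc1)CC`: in a functional assay on A549 cells (Homo sapiens) for inhibition, read by XTT assay, with a stated time of 48 h (on this read-out lower numbers stand for stronger inhibition and higher numbers for weaker inhibition), compound 1 gives > 100000 nM. That value is a limit of the assay and not a number.
Compound 2 `COc1ccc(C(=O)/C(=C/c2c(F)c(F)c(F)c(F)c2F)CCOC(C)=O)cc1`: in this assay compound 2 gives 58100 nM.

Of the two measured compounds, only compound 2 has a real number, so it is the sole fixed point here. Going by the values given here, compound 1 sits at the limit of > 100000 nM in this assay, at which 1 of the 2 values shown sits, which is the only other measured value.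

The next compound, compound 3 `COc1ccc(C(=O)/C(=C/c2c(F)c(F)c(F)c(F)c2F)CC(C)OC(C)=O)cc1`, differs from compound 2 in one place: methyl in place of hydrogen on a saturated chain carbon bound to an oxygen next to a carbonyl group and a saturated chain carbon. Among the compounds with values here, no step between two measured compounds is available, so there is no record of how a change of this size and kind moves the half-maximal inhibitory concentration in this assay. A single methyl group added to a chain is a small change, and with nothing to suggest otherwise the expected step from compound 2 to compound 3 is one that stays within the usual scatter, in no particular direction.

Compound 3 is therefore expected to give 55000 nM, with a range of 20000 nM to 150000 nM, as the estimated step of a 1.1-fold lower number from compound 2 to compound 3 (0.02 log units; within the scatter).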

Compound 3, half-maximal inhibitory concentration: 91700 nM
Estimate against measurement, compound 3: 1.7-fold (0.22 log units) below; the range from low to high includes it.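

In this assay, going by these compounds alone, going from 2-acetoxyethyl to 2-acetoxypropyl gives a 1.6-fold higher number from compound 2 to compound 3 (0.20 log units; within the scatter), and this is the only measured step between two compounds in this set. It shows that methyl in place of hydrogen, on a saturated chain carbon bound to an oxygen next to a carbonyl group and a saturated chain carbon, shifts the number by no more than repeated measurements of one compound would, so compound 2 and compound 3 cannot be ranked against each other. Compound 1 remains a limit of the assay and not a number, so it adds no second step to set beside this one: the limit of > 100000 nM in this assay, at which 1 of the 3 values shown sits.

One methyl at one place leaves open what a longer chain, such as an ethyl group, would do at the same carbon, and whether an amine or a carboxylic acid in place of the acetoxy group would move the number beyond the scatter. A single step also cannot show whether the same methyl would behave in the same way on a different core or in a different cell line.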